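A few compounds are considered here, and "the series" means these few. Any claim that something is new, unique, unknown or untested is made for them only; others in the source may bear on it.

Of the compounds shown here, two have been measured here. Compound 1 `CN1CCC(c2c[nH]c3cnc(NC(=O)c4ccc(F)cc4)cc23)CC1` gives 53 nM in an assay for binding affinity to 5-hydroxytryptamine receptor 1D (Homo sapiens), read by radioligand binding (on this read-out higher numbers stand for weaker inhibition and lower numbers for stronger inhibition), and compound 2 `CN1CCC(c2c[nH]c3ccc(NC(=O)c4ccc(C#N)cc4)nc23)CC1` gives 380 nM, the higher of the two numbers. Compound 3 `CN1CCC(c2c[nH]c3ccc(NC(=O)Nc4ccc(F)cc4)nc23)CC1` has not yet been measured; it differs from compound 2 in one place, ((4-fluorophenyl)amino in place of 4-cyanophenyl on a carbonyl carbon). Without a measured pair sharing this change, compound 3 is expected to show a modest step from compound 2 to compound 3 of a 1.9-fold lower number from compound 2 to compound 3 (0.28 log units; within the scatter), leaning toward a lower number but not clearly beyond the scatter. Compound 3 is therefore estimated at 200 nM, within a range of 50 nM to 800 nM.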

Compound 3, inhibition constant: 3.8 nM
Compound 3: middle estimate off by 53-fold (1.72 log units), on the high side; measured number outside the range, below it.
By their numbers in this assay, from the lowest: compound 3; then compound 1; then compound 2.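

On a carbonyl carbon whose other neighbour is an amide-type nitrogen, (4-fluorophenyl)amino in place of 4-cyanophenyl gives a 100-fold lower number from compound 2 to compound 3 (2.00 log units; beyond the scatter) in this assay. Among these compounds, this shows that the number is highly sensitive to the group at this place, which the earlier compounds could not show because they shared no single-place step. Nothing measured here explains the step.

Still open, going by these compounds, is whether the amino nitrogen or the fluorine carries the step, which 4-fluorophenyl or (4-cyanophenyl)amino at this place would separate. On these data alone, whether a non-aromatic group such as cyclohexylamino would keep the low number is also open.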